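The source may report more compounds than this note shows. Statements on the series, on what has been measured and on what is new or still open speak of the compounds shown alone.

Two compounds of this series have numbers in a functional assay on HT-29 cells (Homo sapiens) for antiproliferative activity, read by MTT assay, with a stated time of 48 h (on this read-out lower numbers stand for stronger inhibition and higher numbers for weaker inhibition), so far. Compound 1 `O=C(/C=C\Nc1ccc(Cl)cc1)c1cn(-c2ccccc2)nc1-c1ccccc1` gives 3610 nM in this assay. Compound 2 `COc1ccc(-c2nn(-c3ccccc3)cc2C(=O)/C=C\Nc2ccc(F)cc2)cc1` gives 7650 nM in this assay, the highest of the two numbers; its nearest neighbour is compound 1, whose number lies lower by a margin beyond the usual scatter. The two differ in more than one place, so no single change can be read from that pair.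

Compound 3 `COc1ccc(-c2nn(-c3ccccc3)cc2C(=O)/C=C\Nc2ccc(Cl)cc2)cc1` is not yet measured in this assay. It differs from compound 2 by chloro in place of fluoro on an aromatic carbon. The same chloro group sits on the corresponding ring of compound 1, which carries the lower number, but compound 1 also differs from compound 2 elsewhere, so that pair gives no clean reading of the fluoro-to-chloro swap alone. The step from compound 2 to compound 3 is therefore expected to be small, if anything towards a lower number, and most likely within the scatter; the estimate is a 1.4-fold lower number from compound 2 to compound 3 (0.14 log units; within the scatter). For compound 3 the expected value in this assay is 5500 nM, within a range from 2200 nM to 13000 nM.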

Compound 3, half-maximal inhibitory concentration: 4760 nM
Estimate against measurement, compound 3: 1.2-fold (0.06 log units) above; low and high end bracket the measured number.
By their numbers in this assay, from the lowest: compounds 1, 3 and 2 (each within the scatter of the next, the first and the last beyond it).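

In this assay, going by these compounds alone, chloro in place of fluoro on this aromatic carbon, para to a large group, gives a 1.6-fold lower number from compound 2 to compound 3 (0.21 log units; within the scatter) and so provides the first clean reading of this swap: at this position the two halogens are not separated. Compound 3 also isolates the other change, with methoxy in place of hydrogen on an aromatic carbon giving a 1.3-fold higher number from compound 1 to compound 3 (0.12 log units; within the scatter), so that change is not resolved either. Each single change stays within the scatter, whereas compound 1 at 3610 nM and compound 2 at 7650 nM, which differ in both places, lie beyond it, and no measurement offered here helps to explain these numbers.

From the compounds shown here alone, with only fluoro and chloro at this position, it remains open whether a bromo, a trifluoromethyl, a nitrile or an amino group would give a step beyond the scatter. Also open, going by these compounds, is how a hydroxy group, a longer alkoxy chain or a carboxylic acid would read in place of the methoxy group.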